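Amide variation on the chlorophenylpiperidine valine series

This account rests on a few compounds, and the source may have more. Where it says the series, first, only, none or still open, it means among the compounds named here.

Measured so far:
- compound 1 `Cc1ccccc1C(=O)N[C@@H](C(=O)N1CCC(c2ccc(Cl)cc2)CC1)C(C)C` — in an assay on THP-1 cells for displacement of a labelled ligand from C-C chemokine receptor type 1 (Homo sapiens) (on this read-out lower numbers stand for stronger inhibition and higher numbers for weaker inhibition), compound 1 gives 32 nM
- compound 2 `CC(C)[C@@H](NC(=O)CCCc1ccccc1)C(=O)N1CCC(c2ccc(Cl)cc2)CC1` — in this assay compound 2 gives 95 nM
- compound 3 `Cc1cccc(CCC(=O)N[C@@H](C(=O)N2CCC(c3ccc(Cl)cc3)CC2)C(C)C)c1` — in this assay compound 3 gives 22 nM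

Compound 3 has the lowest number of the three; against compound 1 its gap is within the scatter (a 1.5-fold lower number from compound 1 to compound 3 (0.16 log units; within the scatter)), and only against compound 2 is it clearly apart (a 4.3-fold lower number from compound 2 to compound 3 (0.64 log units; beyond the scatter)). Compound 4 `CC(C)[C@@H](NC(=O)c1ccc(F)c(F)c1)C(=O)N1CCC(c2ccc(Cl)cc2)CC1` is the next member, not yet measured. It differs from compound 3 in one place: 3,4-difluorophenyl in place of 2-(3-methylphenyl)ethyl on a carbonyl carbon.

For the measured compounds named here, two measured steps bear on this. Replacing a ring on the carbonyl carbon with a two-carbon linker to a ring gave a 1.5-fold lower number from compound 1 to compound 3 (0.16 log units; within the scatter), a step within the scatter, so the loss of the linker by itself is not expected to move the number much. Going by the values given here, compound 1, the only member carrying an aromatic ring directly on the carbonyl carbon, gives 32 nM. Nothing in the series speaks to the two fluorines of the incoming ring. The expected result for compound 4 is therefore a number near that of compound 1, a step of a 1.6-fold higher number from compound 3 to compound 4 (0.20 log units; within the scatter) from compound 3, within the scatter. The estimate for compound 4 in this assay is 35 nM, between 12 nM and 110 nM.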

Compound 4, half-maximal inhibitory concentration: 14 nM
Beside the measured number, compound 4's estimate is 2.5-fold (0.40 log units) above it, and the stated range covers the measured number.
By their numbers in this assay, from the lowest: compounds 4, 3 and 1 (each within the scatter of the next, the first and the last beyond it); then compound 2.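

The position on the carbonyl carbon is sensitive to the substituents of a directly attached aromatic ring: with the 3,4-difluorophenyl group in place of the 2-methylphenyl group, there is a 2.3-fold lower number from compound 1 to compound 4 (0.36 log units; beyond the scatter) in this assay. A chain between the carbonyl carbon and the ring is also shown not to be needed for a low number, as 3,4-difluorophenyl and 2-(3-methylphenyl)ethyl are not separated by a 1.6-fold lower number from compound 3 to compound 4 (0.20 log units; within the scatter), whereas the 3-phenylpropyl group stays clearly apart, with a 6.8-fold lower number from compound 2 to compound 4 (0.83 log units; beyond the scatter). No measured evidence accounts for any of these differences.

Still open, as far as these compounds go, is whether the gain over the 2-methylphenyl group belongs to the two fluorines or simply to the absence of the methyl group, a question that a plain phenyl or a 4-fluorophenyl group on the same carbonyl carbon would address. Also open, from the compounds shown here alone, is how far this position accepts other kinds of group on the ring, such as an amine, a carboxylic acid or a nitrile, and whether the 3,4-difluoro pattern would hold up on a ring carried by a two-carbon chain.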